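The compounds below may be only part of what the source reports. "The series", "measured", "known", "first", "only" and "open" are said of these compounds alone.

Compound 1 `COS(=O)(=O)c1ccc(F)c2ncc(I)cc12` carries a methoxysulfonyl group on its shared core. In an assay for inhibition of methylcytosine dioxygenase TET2 (Homo sapiens), read by mass spectrometry, with stated times of 30 min and 1 h (on this read-out higher numbers stand for weaker inhibition and lower numbers for stronger inhibition), compound 1 gives > 200000 nM, which is a limit of the assay rather than a number. Compound 2 `CCOS(=O)(=O)c1ccc(F)c2ncc(I)cc12` and compound 3 `CCCCCOS(=O)(=O)c1ccc(F)c2ncc(I)cc12` are close relatives of compound 1 in the same series. In this assay compound 2 gives > 200000 nM, again a limit. In this assay compound 3 gives > 200000 nM, also a limit. For the measured compounds named here, the record the limit of > 200000 nM in this assay, at which 3 of the 3 values shown sit, sums this up: every value so far sits at the same limit. The steps a step that the two limits leave unreadable from compound 1 to compound 2, a step that the two limits leave unreadable from compound 1 to compound 3 and a step that the two limits leave unreadable from compound 2 to compound 3 therefore cannot be sized. Compound 4 `NS(=O)(=O)c1ccc(F)c2ncc(I)cc12` differs from compound 1 by amino in place of methoxy on a sulfonyl sulfur. Going by the values given here, none of the measured steps touches the sulfonyl sulfur, so none bears directly on this change, and the limits leave even those steps unsized. Among the compounds with values here, no step of readable size in this assay can be expected in either direction. Compound 4 is therefore estimated at 200000 nM, within 50000 nM to 1000000 nM. That expectation amounts to a step of a number no higher from compound 1 to compound 4 (the limit leaves the size open).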

Compound 4, half-maximal inhibitory concentration: 86600 nM
Beside the measured number, compound 4's estimate is 2.3-fold (0.36 log units) above it; the range from low to high includes it.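

For the compounds shown here, on the sulfonyl sulfur, amino in place of methoxy yields the first readable number of the series in this assay, with an at least 2.3-fold lower number from compound 1 to compound 4 (0.36 log units; beyond the scatter). The other two replacements agree, with an at least 2.3-fold lower number from compound 2 to compound 4 (0.36 log units; beyond the scatter) for amino in place of ethoxy and an at least 2.3-fold lower number from compound 3 to compound 4 (0.36 log units; beyond the scatter) for amino in place of pentyloxy, so this position can move the read-out, although the steps among compound 1, compound 2 and compound 3 cannot be read. Each of the new sizes is only a floor, because each step starts from a limit and not from a number: the limit of > 200000 nM in this assay, at which 3 of the 4 values shown sit.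

The compounds shown leave open whether a methylamino or dimethylamino group on the sulfonyl sulfur would keep the number of compound 4. They also leave open how a carboxylic acid in place of the sulfamoyl group would read.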